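The source may report more compounds than this note shows. Statements on the series, on what has been measured and on what is new or still open speak of the compounds shown alone.

Measured compounds:
- compound 1, `COc1ccc(C2=NO[C@]3(C2)C(=O)O[C@@H]2[C@H]3CC[C@H](C)[C@]3(O)C=CC(=O)[C@@]23C)cc1`: 1.47
- compound 2, `C[C@H]1CC[C@@H]2[C@@H](OC(=O)[C@]23CC(c2ccc(N(C)C)cc2)=NO3)[C@]2(C)C(=O)C=C[C@@]12O`: 1.51

In a physicochemical assay for lipophilicity (a lower number here means a more polar compound, a higher number a more lipophilic compound), compound 1 gives 1.47, the lowest of the two numbers, and compound 2 gives 1.51. Within the data shown here, the only measured step, a number 0.04 log units higher from compound 1 to compound 2 (within the scatter), changes nothing beyond the scatter.

Compound 3, `C[C@H]1CC[C@@H]2[C@@H](OC(=O)[C@]23CC(c2ccccc2Cl)=NO3)[C@]2(C)C(=O)C=C[C@@]12O`, has not yet been measured in this assay. It differs from compound 1 in one place: 2-chlorophenyl in place of 4-methoxyphenyl on a carbon with a double bond to nitrogen. Among the measured compounds shown here, the step from compound 1 to compound 2 does not involve chlorine and tells little here; no measured pair covers this exchange. The entering group carries no hydrogen-bond acceptor, whereas the leaving group carried one, and one heavy atom fewer is present. For the measured compounds named here, on that basis a modest rise is expected, a number 0.58 log units higher from compound 1 to compound 3 (beyond the scatter), though with a wide margin because no measured step, not even a number 0.04 log units higher from compound 1 to compound 2 (within the scatter), matches it. Compound 3 is estimated at 2.05, within 1.55 to 2.55.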

Compound 3, partition coefficient: 2.09
Compound 3: the middle estimate sits 0.04 log units below what was measured; low and high end bracket the measured number.
By their numbers in this assay, from the lowest: compounds 1 and 2 (each within the scatter of the next); then compound 3.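

In this assay, the carbon with a double bond to nitrogen now proves able to carry a change that moves the number beyond the scatter: 2-chlorophenyl in place of 4-methoxyphenyl gives a number 0.62 log units higher from compound 1 to compound 3 (beyond the scatter) and marks the first such shift in this series. The same group in place of 4-(dimethylamino)phenyl gives a number 0.58 log units higher from compound 2 to compound 3 (beyond the scatter), so the rise appears against both earlier groups, whereas exchanging those two groups for each other had stayed within the scatter. Nothing available explains the rise.

Whether the rise goes with the chlorine itself or with the loss of the group carried by the earlier aromatic rings stays open, since a plain phenyl at this carbon is not among the compounds shown. Going by these compounds, how a phenyl bearing a carboxylic acid or a primary amine would read in this assay also remains unknown.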